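Adding a Second 4-Phenylphenyl Group to Compound 2

A few compounds are considered here, and "the series" means these few. Any claim that something is new, unique, unknown or untested is made for them only; others in the source may bear on it.

Among the measured compounds shown here, compound 2 `O=C1OC2(CCN(Cc3ccccc3)CC2)c2c1csc2-c1ccc(-c2ccccc2)cc1` gives 402 nM in an assay on membranes from brain for displacement of a labelled ligand from Sigma non-opioid intracellular receptor 1 (Cavia porcellus), read by scintillation counting, with a stated time of 120 min (on this read-out lower numbers stand for stronger inhibition and higher numbers for weaker inhibition), the higher of the two numbers known so far; compound 1 `N#Cc1ccc(-c2scc3c2C2(CCN(Cc4ccccc4)CC2)OC3=O)cc1` gives 190 nM. For the measured compounds named here, the single measured step, a 2.1-fold higher number from compound 1 to compound 2 (0.33 log units; beyond the scatter), bears only loosely on the change at hand. Compound 3 `O=C1OC2(CCN(Cc3ccccc3)CC2)c2c(-c3ccc(-c4ccccc4)cc3)sc(-c3ccc(-c4ccccc4)cc3)c21` differs from compound 2 by 4-phenylphenyl in place of hydrogen on an aromatic carbon. Going by the values given here, no measured step covers a second 4-phenylphenyl group, so the expectation has no direct precedent and carries wide uncertainty; a modest rise in the number is expected. Compound 3 is therefore estimated at 800 nM, with a range from 250 nM to 3000 nM, an expected step of a 2.0-fold higher number from compound 2 to compound 3 (0.30 log units; within the scatter).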

Compound 3, inhibition constant: > 1000 nM
Compound 3: a limit, no number; the forecaster's own chance of this, stated with the estimate: 10%; middle value at least 1.2-fold (0.09 log units) away from the limit.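

On the aromatic carbon next to the ring sulfur, which carries hydrogen in compound 1 and compound 2, 4-phenylphenyl in place of hydrogen gives an at least 2.4-fold higher number from compound 2 to compound 3 (0.39 log units; beyond the scatter). This shows that a second 4-phenylphenyl group at this position brings no gain in this assay. Compound 3 carries a limit of the assay and not a number: the limit of > 1000 nM in this assay, at which 1 of the 3 values shown sits.

The compounds shown leave open whether methyl, a chlorine atom or an amine on this carbon would also raise the number. They also leave open how high the number of compound 3 truly lies.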